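The source may report more compounds than this note shows. Statements on the series, on what has been measured and on what is new or still open speak of the compounds shown alone.

Measured compounds:
Compound 1 `COc1ccc(C(c2ccc(OC)cc2)N2CCN(C(=O)COc3ccc4ccccc4c3)CC2)cc1` gives 25.6%.
Compound 2 `COc1ccc(OCC(=O)N2CCN(C(c3ccc(C)cc3)c3ccc(C)cc3)CC2)cc1` gives 47.5%.

Of the compounds shown here, two have so far been tested in a functional assay on PC-12 cells (Rattus norvegicus) for cytotoxicity, read by MTT assay, with a stated time of 24 h, tested at 10 uM; a higher number here means a stronger effect of the compound at the concentration tested, a lower number a weaker effect. Compound 1 stands at the lower of the two numbers, with compound 2 sitting a gap above it that lies beyond the usual scatter of this assay. For the measured compounds named here, compound 1 and compound 2 differ in more than one place, so their two values show only that the pair spans a real range, not which part of the structure accounts for it.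

The next compound, compound 3 `COc1ccc(OCC(=O)N2CCN(C(c3ccc(OC)cc3)c3ccc(OC)cc3)CC2)cc1`, is reached from compound 1 by one change: 4-methoxyphenyl in place of naphthalen-2-yl on an oxygen on a saturated carbon. Compound 3 thereby carries the same (4-methoxyphenoxy)methyl group that is present in compound 2, while keeping the diaryl part of compound 1. Going by the values given here, no measured pair isolates this change, so the size of its effect can only be estimated. Given that compound 2, which shares the 4-methoxyphenoxy group, gives 47.5%, an upward step from compound 1 is expected, though of uncertain size. For compound 3 the estimate in this assay is 40%, with a likely range from 22% to 58%. This estimate implies an expected step of a number 14.4 percentage points higher from compound 1 to compound 3 (beyond the scatter), most likely beyond the scatter.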

Compound 3, a percentage reported as activity, at one concentration (the size of the read-out at that concentration, not a potency): 56.7%
Compound 3: the middle estimate sits 16.7 percentage points below what was measured, and the stated range covers the measured number.
By their numbers in this assay, from the lowest: compound 1; then compounds 2 and 3 (each within the scatter of the next).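

For the compounds shown here, compound 1 and compound 3 form the first pair that differs in one place only, so 4-methoxyphenyl in place of naphthalen-2-yl can now be read on its own: in this assay this change gives a number 31.1 percentage points higher from compound 1 to compound 3 (beyond the scatter) and counts as a large step. With the rest of compound 1 held fixed, the group on this oxygen on a saturated carbon is therefore enough by itself to move the read-out beyond the scatter, something the first two compounds, which differ in more than one place, could not show. No measurement on these compounds explains why the read-out moves with this change.

On these data alone, the change also swaps two six-membered aromatic rings for one and brings in a methoxy group, and this single pair cannot separate the two, so it remains open whether a plain phenyl on the same oxygen would behave like 4-methoxyphenyl or like naphthalen-2-yl. As far as these compounds go, it is equally open how the read-out would respond to an amine or a carboxylic acid on that phenyl ring, or to a longer chain in place of the saturated carbon that carries the oxygen.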